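The source may report more compounds than this note shows. Statements on the series, on what has been measured and on what is new or still open speak of the compounds shown alone.

Measured:
compound 1 `Cc1ccc(-c2cs/c(=N/NC(=O)CSc3nnnn3C)n2-c2ccccc2)cc1` — 60.7%
compound 2 `Cc1ccc(-c2cs/c(=N/NC(=O)CSc3nnc(C)s3)n2-c2ccccc2)cc1` — 50.1%

In a functional assay on C6 cells (Rattus norvegicus) for cytotoxicity, read by MTT assay, with a stated time of 24 h, tested at 25 ug/mL (a lower number here means a stronger effect, a higher number a weaker effect of the compound at the concentration tested), compound 1 stands highest of the two numbers; the nearest is compound 2, with a number 10.6 percentage points lower from compound 1 to compound 2 (beyond the scatter). Compound 3 `Cn1nnnc1SCC(=O)N/N=c1/scc(-c2ccccc2)n1-c1ccccc1` is not yet measured in this assay. It differs from compound 1 by hydrogen in place of methyl on an aromatic carbon. Within the data shown here, the one measured step concerns the group on the sulfur and does not touch the six-membered aromatic ring of carbon only, so no measured step bears on this change. The expected step is therefore a number 0.7 percentage points lower from compound 1 to compound 3 (within the scatter), none beyond the scatter. The estimate for compound 3 in this assay is 60%, within a range from 47% to 73%.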

Compound 3, a percentage reported as activity, at one concentration (the size of the read-out at that concentration, not a potency): 64.2%
Beside the measured number, compound 3's estimate is 4.2 percentage points below it; low and high end bracket the measured number.
By their numbers in this assay, from the lowest: compound 2; then compounds 1 and 3 (each within the scatter of the next).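

Going from 4-methylphenyl to phenyl gives a number 3.5 percentage points higher from compound 1 to compound 3 (within the scatter) in this assay and is the first reading on the six-membered aromatic ring of carbon only. Within the compounds shown, the methyl at this place can go without a change beyond the scatter, while a number 10.6 percentage points lower from compound 1 to compound 2 (beyond the scatter) remains the only step beyond it. No available evidence bears on this result.

Open, going by these compounds, is whether an amine, a methoxy group or a carboxylic acid at this place would shift the read-out. Also open, on these data alone, is how phenyl combines with 5-methyl-1,3,4-thiadiazol-2-yl on the sulfur.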